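The source may report more compounds than this note shows. Statements on the series, on what has been measured and on what is new or still open speak of the compounds shown alone.

Measured compounds:
compound 1 `O=C1C=C(NCc2ccccc2)C(=O)c2c1nc1n2[C@H]2OC[C@@H](O)[C@H]2OC1` — > 8000 nM
compound 2 `CCc1ccc(NC2=CC(=O)c3c(nc4n3[C@H]3OC[C@@H](O)[C@H]3OC4)C2=O)cc1` — > 4000 nM

Both values come from a functional assay on ECa-109 cells for inhibition, with ECa-109 cell line (Homo sapiens) as the target, read by sulforhodamine B assay; on this read-out higher numbers stand for weaker inhibition and lower numbers for stronger inhibition. In this assay compound 1 gives > 8000 nM, which is a limit of the assay and not a number. In this assay compound 2 likewise gives > 4000 nM, again a limit rather than a number. Within the data shown here, compound 2 thus stands at the limit of > 4000 nM in this assay, at which 1 of the 2 values shown sits, while the one other value shown sits at the limit of > 8000 nM in this assay, at which 1 of the 2 values shown sits; no numerical comparison between the two measured compounds is possible, and no step between them can be stated.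

Compound 3 `O=C1C(Nc2cccc(Cl)c2)=CC(=O)c2c1nc1n2[C@H]2OC[C@@H](O)[C@H]2OC1` is not yet measured. It differs from compound 2 by 3-chlorophenyl in place of 4-ethylphenyl on an amine nitrogen. Nothing in the two values shown supports an expected step in this assay beyond the scatter in either direction. Compound 3 is therefore expected to remain at or near the limit, with an estimated 8000 nM (range 2000 nM to 30000 nM). The estimated step is a step that the limit leaves unreadable from compound 2 to compound 3, expected to lie within the scatter.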

Compound 3, half-maximal inhibitory concentration: 3080 nM
Estimate against measurement, compound 3: 2.6-fold (0.41 log units) above; the measured number falls inside the stated range.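

In this assay, among these compounds, compound 3 gives 3080 nM, the first reading in these notes that is a number, with (3-chlorophenyl)amino in place of (4-ethylphenyl)amino on the amine nitrogen. Compound 2 stays a limit and not a number: the limit of > 4000 nM in this assay, at which 1 of the 3 values shown sits. The change gives an at least 1.2-fold lower number from compound 2 to compound 3 (0.11 log units; that floor lies within the scatter), so this position tolerates the swap and gives a readable value, but a real gain is not established and the true step could be larger.

The compounds shown do not separate the part played by the chlorine from that of the lost ethyl group, since each aryl group differs from the other in more than one feature. On these data alone, how a methoxy group, a carboxylic acid or a longer chain on the phenyl ring would read in this assay remains open.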